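The source may report more compounds than this note shows. Statements on the series, on what has been measured and on what is new or still open speak of the compounds shown alone.

Measured in an assay on HEK293 cells for positive allosteric modulation of metabotropic glutamate receptor 2 (Rattus norvegicus), read by thallium flux, with a stated time of 2.5 min; on this read-out higher numbers stand for larger maximal responses and lower numbers for smaller maximal responses:
compound 1 `Cc1c(OCCCCOc2ccc(C(=O)C(C)C)c(O)c2C)cccc1C(=O)O` gives 66.9%
compound 2 `CCC(=O)c1ccc(OCCCCOc2cc(C(=O)O)ccc2OC)c(C)c1O` gives 72.6%
compound 3 `COc1ccc(C(=O)O)cc1OCCCCOc1ccc(C(=O)C(C)C)c(O)c1C` gives 66.6%

Compound 1 and compound 3 sit within the scatter of each other; the values of compound 2 and compound 3 are also within the scatter. Within the data shown here, the one counted change in the set, (hydrogen in place of methyl on a saturated chain carbon bound to a carbonyl carbon and a saturated chain carbon), produced a number 6 percentage points higher from compound 3 to compound 2 (within the scatter). The difference between the core of compound 1 and the core of compound 3 is not broken down here.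

Compound 4 `CCC(=O)c1ccc(OCCCCOc2cccc(C(=O)O)c2C)c(C)c1O` has not been measured. It arises from compound 1 by hydrogen in place of methyl on a saturated chain carbon bound to a carbonyl carbon and a saturated chain carbon, the same change as from compound 3 to compound 2, at a place described in the same words. For compound 4 the expected step is a number 5.1 percentage points higher from compound 1 to compound 4 (within the scatter), resting on the size of a number 6 percentage points higher from compound 3 to compound 2 (within the scatter). Compound 4 is therefore estimated at 72%, with a range from 60% to 85%.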

Compound 4, largest response reached (reported as percent of maximum), in percent of the reference or control that the assay uses: 71.3%
Compound 4: middle estimate off by 0.7 percentage points, on the high side, within the range that was stated.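

In this assay, the change from isopropylcarbonyl to propanoyl on the core of compound 1 gives a number 4.4 percentage points higher from compound 1 to compound 4 (within the scatter). Set beside the same change on the other core, the two steps do not differ: the same change on two cores in this assay, a number 6 percentage points higher (within the scatter) from compound 3 to compound 2 and a number 4.4 percentage points higher (within the scatter) from compound 1 to compound 4, 1.6 percentage points apart, within the scatter of two such steps. This supports carrying the change between these two cores with no visible dependence on the core, but with both steps within the scatter it does not show that the change itself raises the maximal response, and two cores cannot establish a rule for the series.

Still open, going by these compounds, is whether a longer acyl chain such as butanoyl, or a cyclopropyl group on the carbonyl, would move the response beyond the scatter. The compounds shown also leave open what a tetrazole or an amide would do in place of the carboxylic acid.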